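The source may report more compounds than this note shows. Statements on the series, on what has been measured and on what is new or still open speak of the compounds shown alone.

The measured set comprises three compounds, each tested in an ADME assay on HEL cells (Homo sapiens) for cytotoxicity, with a stated time of 3 days; a higher number here means that more compound is tolerated, a lower number that less compound is tolerated:

Compound 1, `O=S1(=O)C=C(OCc2ccccc2)C(Cc2ccccc2)(Cc2ccccc2)O1`: 200000 nM
Compound 2, `CCC1(Cc2ccccc2)OS(=O)(=O)C=C1OC(=O)c1ccccc1`: an assay limit of > 200000 nM, not a number
Compound 3, `CCC1(Cc2ccccc2)OS(=O)(=O)C=C1OCCCc1ccccc1`: 133000 nM

Among these, compound 1 stands at one of the two numbers that were actually obtained. The other number, that of compound 3, lies within the scatter of compound 1, so the two cannot be told apart. The third compound, compound 2, gives only a limit in this assay; one of the three values shown sits at the limit of > 200000 nM in this assay, at which 1 of the 3 values shown sits.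

The next compound to be measured is compound 4, `CC(C)C1(Cc2ccccc2)OS(=O)(=O)C=C1OCc1ccccc1`. It differs from compound 1 in one place: isopropyl in place of benzyl on a saturated ring carbon. For the measured compounds named here, no step between two measured compounds of this set is available to calibrate such a change, since no pair differs in a single place. With all three measured values sitting at or near the same level, no step beyond the scatter is expected in this assay in either direction.

Compound 4 is therefore estimated at 180000 nM, with a range from 90000 nM to 250000 nM, which means an expected step of a 1.1-fold lower number from compound 1 to compound 4 (0.05 log units; within the scatter).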

Compound 4, half-maximal cytotoxic concentration: 200000 nM
Compound 4: middle estimate off by 1.1-fold (0.05 log units), on the low side; low and high end bracket the measured number.
By their numbers in this assay, from the lowest: compounds 3, 1 and 4 (each within the scatter of the next).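

In this assay, the set now holds its first pair that differs in one place, and isopropyl in place of benzyl on a saturated ring carbon gives no change at the digits printed from compound 1 to compound 4 (within the scatter). This position, next to the ring oxygen, therefore takes a group of 3 heavy atoms with no ring in place of one of 7 heavy atoms with a six-membered aromatic ring, and the read-out does not register the difference. This is a single step, so it holds for this pair only and sets no rule for the position.

Compound 2 still gives a limit and not a number: the limit of > 200000 nM in this assay, at which 1 of the 4 values shown sits.

Going by these compounds, whether an amine, a carboxylic acid or a longer chain on this same ring carbon would leave the half-maximal cytotoxic concentration equally unmoved remains open, as does any answer for a change at another place on the shared core.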